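The compounds below may be only part of what the source reports. "The series", "measured", "known", "first", "only" and "open" are said of these compounds alone.

Series notes. Among the compounds with values here, in an assay for binding affinity to Neuronal acetylcholine receptor; alpha4/beta2 (Rattus norvegicus) (a lower number here means a stronger inhibitor, a higher number a weaker inhibitor), compound 3 `Clc1ncc(OCC2CCN2)cc1/C=C/c1ccncc1` gives 0.009 nM, the lowest number of the three measured so far. Compound 1 `Clc1ncc(OCC2CCCN2)cc1/C=C/c1ccncc1` gives 0.015 nM, and the step of a 1.7-fold lower number from compound 1 to compound 3 (0.22 log units; within the scatter) is small. Compound 2 `CN1CCCC1COc1cnc(Cl)c(/C=C/c2ccncc2)c1` gives 0.028 nM, and the step of a 3.1-fold lower number from compound 2 to compound 3 (0.49 log units; beyond the scatter) is the only one beyond the scatter. Compound 4 `CN1CCC1COc1cnc(Cl)c(/C=C/c2ccncc2)c1` differs from compound 3 by methyl in place of hydrogen on an amine nitrogen in a ring. Within the data shown here, the one measured step of the same kind, a 1.9-fold higher number from compound 1 to compound 2 (0.27 log units; within the scatter), added a methyl on a ring amine nitrogen and stayed within the scatter. For compound 4 the expected step is therefore small and upward in the number, if anything, namely a 1.7-fold higher number from compound 3 to compound 4 (0.22 log units; within the scatter). In this assay compound 4 is estimated at 0.015 nM, with a range from 0.006 nM to 0.04 nM.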

Compound 4, inhibition constant: 0.072 nM
Compound 4: middle estimate off by 4.8-fold (0.68 log units), on the low side, outside the stated range (above it).
By their numbers in this assay, from the lowest: compounds 3, 1 and 2 (each within the scatter of the next, the first and the last beyond it); then compound 4.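

In this assay, an 8.0-fold higher number from compound 3 to compound 4 (0.90 log units; beyond the scatter) shows that methyl in place of hydrogen on an amine nitrogen in a ring is not a neutral change on the four-membered non-aromatic ring. The size of this change depends on the ring that carries it: the same change on two cores in this assay, a 1.9-fold higher number (0.27 log units; within the scatter) from compound 1 to compound 2 and an 8.0-fold higher number (0.90 log units; beyond the scatter) from compound 3 to compound 4, 4.3-fold (0.63 log units) apart, beyond the scatter of two such steps. With the methyl present, ring size also shows, at a 2.6-fold higher number from compound 2 to compound 4 (0.41 log units; beyond the scatter), while a 4.8-fold higher number from compound 1 to compound 4 (0.68 log units; beyond the scatter) is likewise beyond the scatter, unlike the step between the two rings with hydrogen on nitrogen.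

The compounds shown do not tell why the methyl counts for more on the four-membered ring. From the compounds shown here alone, whether an ethyl on the same nitrogen would raise the number further also stays open.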